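A few compounds are considered here, and "the series" means these few. Any claim that something is new, unique, unknown or untested is made for them only; others in the source may bear on it.

Values so far in a functional assay on U-87MG ATCC cells for inhibition, with U-87 MG (Homo sapiens) as the target, read by sulforhodamine B assay, with a stated time of 72 h; a higher number here means a weaker inhibitor of growth, a lower number a stronger inhibitor of growth:
- compound 1 `COc1ncc(-c2ccc3nccc(/C(C)=C/C(=O)N4CCN(C)CC4)c3c2)cc1NS(=O)(=O)c1ccc(F)cc1F` gives 140 nM
- compound 2 `COc1ncc(-c2ccc3nccc(/C(C)=C/C(=O)N4CCOCC4)c3c2)cc1NS(=O)(=O)c1ccc(F)cc1F` gives 610 nM

Of the two, compound 2 has the higher number (610 nM) and is the weaker inhibitor of growth, with a gap to compound 1 beyond the scatter. Compound 3 `COc1ncc(-c2ccc3nccc(/C(C)=C/C(=O)N4CCC(O)CC4)c3c2)cc1NS(=O)(=O)c1ccc(F)cc1F` has not yet been measured. It differs from compound 2 at one place, with 4-hydroxypiperidin-1-yl in place of morpholin-4-yl on a carbonyl carbon.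

Among the measured compounds shown here, only one measured step touches this place: a 4.4-fold higher number from compound 1 to compound 2 (0.64 log units; beyond the scatter) (morpholin-4-yl in place of 4-methylpiperazin-1-yl on a carbonyl carbon). It is modest but beyond the scatter. For the measured compounds named here, it shows that the group on the carbonyl carbon can move the number in this assay, but no measured compound carries 4-hydroxypiperidin-1-yl, so it gives neither size nor direction for the new change. No step beyond the scatter is therefore expected, with at most a slight lean towards a lower number. The expected move is a 1.5-fold lower number from compound 2 to compound 3 (0.16 log units; within the scatter) (an estimate). For compound 3 the estimated value is 420 nM (expected range 170 nM to 1100 nM).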

Compound 3, concentration for 50% growth inhibition: 600 nM
Estimate against measurement, compound 3: 1.4-fold (0.15 log units) below; low and high end bracket the measured number.
By their numbers in this assay, from the lowest: compound 1; then compounds 3 and 2 (each within the scatter of the next).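

In this assay, 4-hydroxypiperidin-1-yl in place of morpholin-4-yl on the carbonyl carbon gives a 1.0-fold lower number from compound 2 to compound 3 (0.01 log units; within the scatter), so at this place the two rings are not told apart, even with the added hydrogen-bond donor and the extra heavy atom. Against 4-methylpiperazin-1-yl, 4-hydroxypiperidin-1-yl gives a 4.3-fold higher number from compound 1 to compound 3 (0.63 log units; beyond the scatter), close in size to a 4.4-fold higher number from compound 1 to compound 2 (0.64 log units; beyond the scatter); among these three compounds, 4-methylpiperazin-1-yl alone stands apart, and compound 1 keeps the lowest number, with compound 2 and compound 3 level above it. No supporting data are available to explain this separation.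

On these data alone, it remains open whether the lower number follows the 4-methylpiperazin-1-yl ring as a whole or its methyl-bearing nitrogen, and whether an unsubstituted piperazin-1-yl or a 4-(dimethylamino)piperidin-1-yl on the carbonyl carbon would fall with compound 1 or with compound 2 and compound 3. Also open, as far as these compounds go, is how a carboxylic acid on the piperidine ring, or a longer chain ending in an amine, would read at this place in this assay.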